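This account rests on a few compounds, and the source may have more. Where it says the series, first, only, none or still open, it means among the compounds named here.

Going by the values given here, in an ADME assay on HepG2 2.2.15 cells (Homo sapiens) for cytotoxicity (on this read-out higher numbers stand for lower toxicity in this test and lower numbers for higher toxicity in this test), compound 2 `O=C(CN1C(=O)c2ccccc2C1=O)OCCc1c(-c2ccccc2Cl)c2cc(Cl)ccc2[nH]c1=O` gives 960000 nM, the only actual number measured so far. Compound 1 `CC12CCC(C(=O)OCCc3c(-c4ccccc4Cl)c4cc(Cl)ccc4[nH]c3=O)(OC1=O)C2(C)C` reads > 1800000 nM, and this is a limit of the assay, not a number. Compound 3 `O=C(CCOc1ccccc1)OCCc1c(-c2ccccc2Cl)c2cc(Cl)ccc2[nH]c1=O` keeps the shared core of compound 2 and changes one side group: a group of 8 heavy atoms (7 carbon, 1 oxygen; one six-membered aromatic ring of carbon only) in place of a group of 11 heavy atoms (8 carbon, 1 nitrogen, 2 oxygen; one five-membered non-aromatic ring with 1 hetero atom, one six-membered aromatic ring of carbon only), on a saturated chain carbon bound to a carbonyl carbon. Among the compounds with values here, the one measured step, an at least 1.8-fold lower number from compound 1 to compound 2 (0.27 log units; that floor lies within the scatter), also swapped a group, though on a carbonyl carbon rather than on the saturated chain carbon changed here, so it is only a loose guide. It offers no sign of a large swing, and no change beyond the scatter is expected in this assay. The expected change is a 1.1-fold lower number from compound 2 to compound 3 (0.03 log units; within the scatter), an estimate that stays within the scatter. For compound 3 the estimated value is 900000 nM, with an expected range from 400000 nM to 1800000 nM.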

Compound 3, half-maximal cytotoxic concentration: 46000 nM
Beside the measured number, compound 3's estimate is 20-fold (1.29 log units) above it; measured number outside the range, below it.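

In this assay, this place proves sensitive: a 21-fold lower number from compound 2 to compound 3 (1.32 log units; beyond the scatter), so a swap on the saturated chain carbon bound to a carbonyl carbon can move the read-out well beyond the scatter, something the earlier step, with its floor inside the scatter, could not show. The move runs towards higher toxicity in this test, with phenoxymethyl entering and the group with the five-membered non-aromatic ring leaving. The second step, an at least 39-fold lower number from compound 1 to compound 3 (1.59 log units; beyond the scatter), is large as well, but its size is only a floor because it starts from a limit of the assay, not a number: the limit of > 1800000 nM in this assay, at which 1 of the 3 values shown sits.

The compounds shown cannot separate the part played by the oxygen of phenoxymethyl from that of its aromatic ring. From the compounds shown here alone, it also remains open how a plain methyl, an amine or a carboxylic acid at this place would read.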